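Benzotriazine dioxide series: chain and aryl variants on the ether

This account rests on a few compounds, and the source may have more. Where it says the series, first, only, none or still open, it means among the compounds named here.

Measured compounds
- compound 1 `CCCOCNc1n[n+]([O-])c2cc(OC)ccc2[n+]1[O-]`: 2810 nM
- compound 2 `CCCCCOCNc1n[n+]([O-])c2ccccc2[n+]1[O-]`: 6460 nM
- compound 3 `[O-][n+]1nc(NCOCc2ccc(Cl)cc2)[n+]([O-])c2ccccc21`: 1470 nM

In a functional assay on A549 cells (Homo sapiens) for cytotoxicity, read by MTT assay, with a stated time of 72 h (a higher number here means a weaker inhibitor, a lower number a stronger inhibitor), compound 3 gives 1470 nM and stands lowest of the three numbers; compound 1 sits nearest, within the scatter of it, and compound 2 sits furthest, beyond the scatter. The unmeasured compound 4 `CCCOCNc1n[n+]([O-])c2ccccc2[n+]1[O-]` differs from compound 3 in one place: ethyl in place of 4-chlorophenyl on a saturated chain carbon bound to an oxygen on a saturated carbon. For the measured compounds named here, only one measured step bears on this change, the replacement of butyl by 4-chlorophenyl at the same place, which gave a 4.4-fold lower number from compound 2 to compound 3 (0.64 log units; beyond the scatter). Going by the values given here, the change to compound 4 runs the other way, from the aryl back to a short alkyl, so a higher number than compound 3 is expected in this assay, although compound 4 also has a shorter chain than compound 2 and no methoxy on the core of compound 1, for which no step is known. The step from compound 3 to compound 4 is estimated at a 2.9-fold higher number from compound 3 to compound 4 (0.46 log units; beyond the scatter). Compound 4 is expected to give 4200 nM, within 2000 nM to 9000 nM.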

Compound 4, half-maximal inhibitory concentration: 7460 nM
The estimate for compound 4 lay 1.8-fold (0.25 log units) below the measured number; the measured number falls inside the stated range.
By their numbers in this assay, from the lowest: compounds 3 and 1 (each within the scatter of the next); then compounds 2 and 4 (each within the scatter of the next).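

In this assay, ethyl in place of 4-chlorophenyl on a saturated chain carbon bound to an oxygen on a saturated carbon gives a 5.1-fold higher number from compound 3 to compound 4 (0.71 log units; beyond the scatter) and so shows that the lower number of compound 3 holds against a second alkyl group, not only against butyl. The two alkyl ethers do not separate, with a 1.2-fold higher number from compound 2 to compound 4 (0.06 log units; within the scatter) leaving butyl and ethyl within the scatter of each other, so in this pair the length of the alkyl chain does not move the number. On the core, hydrogen in place of methoxy on an aromatic carbon gives a 2.7-fold higher number from compound 1 to compound 4 (0.42 log units; beyond the scatter) and thus adds a second place where a change moves the number beyond the scatter.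

The compounds shown leave open whether the lower number of compound 3 comes with the aryl ring or with its chlorine, which an unsubstituted phenyl would separate, and whether methoxy on the core adds to 4-chlorophenyl on the chain. No supporting measurement bears on why any of these steps arises.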